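Changing the ring on the piperidine nitrogen of compound 3

The compounds below may be only part of what the source reports. "The series", "measured", "known", "first", "only" and "open" are said of these compounds alone.

The series shares one core and differs at the nitrogen of a six-membered non-aromatic ring. Compound 1 `CC(C)(C)OC(=O)N1CCC(CCNC(=O)N2CCc3cc(S(C)(=O)=O)ccc32)CC1` gives 2500 nM in a functional assay on CHO cells for agonist activity at Glucose-dependent insulinotropic receptor (Homo sapiens), read by a luciferase reporter and cAMP accumulation, with a stated time of 2 h; on this read-out higher numbers stand for an effect only at larger amounts of compound and lower numbers for an effect already at smaller amounts. Compound 2 `CC(C)OC(=O)N1CCC(Oc2cc(N3CCc4cc(S(C)(=O)=O)ccc43)ncn2)CC1` gives 17 nM in this assay, and compound 3 `CCc1cnc(N2CCC(Oc3cc(N4CCc5cc(S(C)(=O)=O)ccc54)ncn3)CC2)nc1` gives 11 nM; compound 3 thus carries the lowest of the three numbers shown, though its step to compound 2 is within the scatter. For the measured compounds named here, the only step at this position, a 1.5-fold lower number from compound 2 to compound 3 (0.19 log units; within the scatter), shows that exchanging the carbamate there for an aromatic ring moved the number little. Compound 4 `CC(C)c1noc(N2CCC(Oc3cc(N4CCc5cc(S(C)(=O)=O)ccc54)ncn3)CC2)n1` differs from compound 3 by 3-isopropyl-1,2,4-oxadiazol-5-yl in place of 5-ethylpyrimidin-2-yl on an amine nitrogen in a ring. Going by the values given here, no measured step exchanges one aromatic ring for another at this nitrogen, so the single step from compound 2 to compound 3 is the nearest guide. Because a 1.5-fold lower number from compound 2 to compound 3 (0.19 log units; within the scatter) was within the scatter, compound 4 is expected to stay close to compound 3, with a step of a 1.5-fold higher number from compound 3 to compound 4 (0.16 log units; within the scatter) in this assay. Compound 4 is therefore estimated at 16 nM, within a range of 5 nM to 50 nM.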

Compound 4, half-maximal effective concentration in the Glucose-dependent insulinotropic receptor assay: 7.7 nM
The estimate for compound 4 lay 2.1-fold (0.32 log units) above the measured number; the range from low to high includes it.
By their numbers in the Glucose-dependent insulinotropic receptor assay, from the lowest: compounds 4, 3 and 2 (each within the scatter of the next, the first and the last beyond it); then compound 1.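

In the Glucose-dependent insulinotropic receptor assay, the five-membered 3-isopropyl-1,2,4-oxadiazol-5-yl ring matches the six-membered 5-ethylpyrimidin-2-yl ring on the amine nitrogen, with a 1.4-fold lower number from compound 3 to compound 4 (0.15 log units; within the scatter), so this position tolerates either aromatic ring in this assay. Against the isopropoxycarbonyl group, the 3-isopropyl-1,2,4-oxadiazol-5-yl ring gives the first step at this nitrogen that lies beyond the scatter, though a modest one, with a 2.2-fold lower number from compound 2 to compound 4 (0.34 log units; beyond the scatter). In a physicochemical assay for lipophilicity, read by HPLC, measured as octanol-water partition, at pH 7.4 (on this read-out lower numbers stand for lower lipophilicity and higher numbers for higher lipophilicity), compound 3 gives 3.8 and compound 4 gives 3.1. The same exchange of aromatic rings does separate the two compounds in the physicochemical assay: the measured distribution coefficient of compound 3, 3.8, and of compound 4, 3.1, a number 0.70 log units lower (beyond the scatter).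

The compounds shown leave open whether that difference in distribution coefficient follows the ring itself or the alkyl group it carries. A 1,2,4-oxadiazol-5-yl ring bearing an ethyl group, or a pyrimidin-2-yl ring bearing an isopropyl group, would tell these two apart.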